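The source may report more compounds than this note shows. Statements on the series, on what has been measured and on what is new or still open speak of the compounds shown alone.

Working notes on the series.

Three compounds carry a structure here: compound 1 `O=C(/C=C/c1ccc(COc2ccccc2)cc1)NO`, compound 2 `Nc1ccccc1NC(=O)c1ccc(COc2ccc(Br)cc2)cc1` and compound 3 `Nc1ccccc1NC(=O)c1ccc(COc2ccccc2)cc1`. In a functional assay on MGC-803 cells (Homo sapiens) for antiproliferative activity, read by CCK-8 assay, with a stated time of 72 h (a lower number here means a stronger inhibitor, a higher number a weaker inhibitor), compound 1 gives "not determined" (no result reported). In this assay compound 2 gives > 32000 nM, which is a limit of the assay and not a number, the case described by the limit of > 32000 nM in this assay, at which 1 of the 3 values shown sits. In this assay compound 3 gives 5670 nM, the only plain number shown, so compound 3 stands alone as the reference point for the series.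

For the measured compounds named here, the one measured step, an at least 5.6-fold lower number from compound 2 to compound 3 (0.75 log units; beyond the scatter), concerns the phenoxy ring and tells nothing direct about the aminophenyl ring. Compound 4 `Nc1cc(F)ccc1NC(=O)c1ccc(COc2ccccc2)cc1` differs from compound 3 only there: fluoro in place of hydrogen on an aromatic carbon. Going by the values given here, no measured step bears on a change at this position, so the expectation rests on the size of the change alone, a single fluorine entering with no donor or acceptor and no charge.

The step of a 1.1-fold lower number from compound 3 to compound 4 (0.05 log units; within the scatter) is therefore expected to stay within the scatter, in no clear direction. For compound 4 in this assay the estimate is 5000 nM, with a range from 1500 nM to 16000 nM.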

Compound 4, half-maximal inhibitory concentration: 6020 nM
Compound 4: the middle estimate sits 1.2-fold (0.08 log units) below what was measured; the range from low to high includes it.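

The step from 2-aminophenyl to 2-amino-4-fluorophenyl gives the series its first reading on this ring: in this assay, the result is a 1.1-fold higher number from compound 3 to compound 4 (0.03 log units; within the scatter). For the compounds shown here, compound 3 and compound 4 therefore cannot be told apart in this read-out, so a single fluoro meta to the amino group and para to the large group leaves the antiproliferative reading within the scatter, whereas the only earlier step, the exchange of bromo for hydrogen on the phenoxy ring, lay beyond it. What is known about the compounds offers no measured property that bears on this result.

On these data alone, whether this place stays equally quiet with groups other than fluoro, such as chloro, methoxy, trifluoromethyl or a carboxylic acid, remains open, and one fluoro at one place says nothing about the other open carbons of the ring. Also open is whether the same fluoro would read the same way on a phenoxy ring carrying bromo or another substituent, as the shown steps each change a single ring on the unsubstituted parent, compound 3.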